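A few compounds are considered here, and "the series" means these few. Any claim that something is new, unique, unknown or untested is made for them only; others in the source may bear on it.

Measured so far in a functional assay on MCF7 cells (Homo sapiens) for inhibition, read by CCK-8 assay, with a stated time of 48 h; a lower number here means a stronger inhibitor of growth, a higher number a weaker inhibitor of growth:
- compound 1 `Cc1ccc(Nc2ncc(Cl)c(Nc3ccccc3C)n2)cc1`: > 100000 nM (a limit)
- compound 2 `Cc1ccccc1Nc1nc(Nc2ccccn2)ncc1Cl`: 31400 nM
- compound 3 `Cc1ccccc1Nc1nc(NCc2ccncc2)ncc1Cl`: > 100000 nM (a limit)

Compound 1 has a limit and not a number, which is the limit of > 100000 nM in this assay, at which 2 of the 3 values shown sit.

Compound 4 `Cc1ccccc1Nc1nc(Nc2ccc(N3CCCN(C)CC3)cc2)ncc1Cl` has 4-methyl-1,4-diazepan-1-yl in place of methyl on an aromatic carbon, para to a large group: 4-methyl-1,4-diazepan-1-yl in place of methyl on an aromatic carbon.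

Within the data shown here, no measured step makes this exact change. The nearest evidence is an at least 3.1-fold lower number from compound 1 to compound 2 (0.50 log units; beyond the scatter), which replaces the whole 4-methylphenyl group with pyridin-2-yl and lies beyond the scatter. Against it stands an at least 3.1-fold higher number from compound 2 to compound 3 (0.50 log units; beyond the scatter), also beyond the scatter, so a lower number is not general to changes at this nitrogen. In this assay, a step of at least modest size towards a lower number is therefore expected, with low confidence, and the limit on compound 1 leaves its size open.

For compound 4, the expected value is 20000 nM, with an estimated range of 4000 nM to 100000 nM. The estimated change is an at least 5.0-fold lower number from compound 1 to compound 4 (0.69 log units; beyond the scatter).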

Compound 4, concentration for 50% growth inhibition: 4290 nM
Beside the measured number, compound 4's estimate is 4.7-fold (0.67 log units) above it; measured number inside the range.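

In this assay, placing 4-methyl-1,4-diazepan-1-yl in place of methyl on the aromatic carbon, para to a large group, gives an at least 23-fold lower number from compound 1 to compound 4 (1.36 log units; beyond the scatter). The earlier readable steps replaced the whole group on the nitrogen and were of at least modest size, whereas this one keeps the six-membered aromatic ring, changes only what it carries, and is large, so this carbon is a place where a change registers strongly. The value of compound 1 is a limit: the limit of > 100000 nM in this assay, at which 2 of the 4 values shown sit.

Still open, on these data alone, is whether the seven-membered ring itself matters, or whether a six-membered 4-methylpiperazin-1-yl or an open-chain dimethylamino group at the same carbon would read alike. Also open, as far as these compounds go, is how a carboxylic acid at this carbon would read in this assay.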